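The source may hold more compounds than are shown below. What is called first, only, known or untested is meant among the compounds shown, and "the series" means these compounds.

Within the data shown here, compound 1 (`OC(c1cccs1)c1cc2ccccc2nc1Cl`) is the only compound in this small set with a number. In a functional assay on HepG2 cells (Homo sapiens) for inhibition, read by WST assay, with stated times of 72 h and 2 h (a higher number here means a weaker inhibitor, a lower number a stronger inhibitor), compound 1 gives a half-maximal inhibitory concentration of 80800 nM and so stands alone on the scale, with nothing to rank it against. Compound 2 (`Cc1ccc(-c2cc(COC(c3cccs3)c3cc4ccccc4nc3Cl)on2)cc1`) is recorded as "not active" (no number reported) in this assay and has no number. Compound 3 (`FC(F)(F)c1cccc(COC(c2cccs2)c2cc3ccccc3nc2Cl)c1`) is recorded as "not active" (no number reported) in the same test, again without a number. Both of these carry a larger group on the oxygen where compound 1 has its hydrogen.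

Compound 4 (`Fc1ccc(COC(c2cccs2)c2cc3ccccc3nc2Cl)cc1`) has yet to be measured. It differs from compound 1 by a single change (4-fluorobenzyl in place of hydrogen on an oxygen on a saturated carbon), with 4-fluorobenzyl in place of hydrogen on an oxygen on a saturated carbon. Among the measured compounds shown here, no measured pair shows the size of such a step, so any expectation here is loose. No step beyond the usual scatter is expected, and the expected step is a 1.3-fold lower number from compound 1 to compound 4 (0.13 log units; within the scatter) with no firm direction. Compound 2 and compound 3 both came back without a number, so compound 4 may well do the same. If a number does appear, the estimate for compound 4 is 60000 nM and the expected range runs from 15000 nM to 120000 nM in this test.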

Compound 4, half-maximal inhibitory concentration: "not active" (no number reported)
Compound 4: no number reported, so the estimate cannot be set against anything.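

Among these compounds, compound 4, like compound 2 and compound 3, is recorded as not active without a number in this assay so no step from compound 1 to any of them can be read. The compounds shown leave open how far a larger group in place of the hydrogen on the oxygen of compound 1 moves the inhibitory concentration. No supporting data bear on this result.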